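Aryl swap at the chain carbon: compound 3 to compound 4

The source may report more compounds than this note shows. Statements on the series, on what has been measured and on what is new or still open speak of the compounds shown alone.

The series shares one core and varies the aryl group on a double-bonded chain carbon bound to a double-bonded ring carbon. In a functional assay on SW-620 cells (Homo sapiens) for cytotoxicity, read by MTT assay, with a stated time of 3 days (on this read-out lower numbers stand for an effect already at smaller amounts and higher numbers for an effect only at larger amounts of compound), compound 1 `O=C1/C(=C/c2cccc(Cl)c2)c2ccccc2N1c1c(Cl)cccc1Cl` gives 50 ug/mL, compound 2 `O=C1/C(=C/c2ccc(Cl)cc2Cl)c2ccccc2N1c1c(Cl)cccc1Cl` gives 2 ug/mL, and compound 3 `O=C1/C(=C/c2ccccc2[N+](=O)[O-])c2ccccc2N1c1c(Cl)cccc1Cl` gives 90 ug/mL. Compound 3 thus shows the highest of the three numbers in this assay; its nearest neighbour is compound 1, separated by a step within the scatter (a 1.8-fold higher number from compound 1 to compound 3 (0.26 log units; within the scatter)), while compound 2 lies furthest off (a 45-fold higher number from compound 2 to compound 3 (1.65 log units; beyond the scatter)).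

Compound 4 `O=C1/C(=C/c2ccc(O)cc2)c2ccccc2N1c1c(Cl)cccc1Cl` differs from compound 3 only at this position: 4-hydroxyphenyl in place of 2-nitrophenyl on a double-bonded chain carbon bound to a double-bonded ring carbon. All three measured steps concern the same position. Two of them were large, a 25-fold lower number from compound 1 to compound 2 (1.40 log units; beyond the scatter) and a 45-fold higher number from compound 2 to compound 3 (1.65 log units; beyond the scatter), one was not, a 1.8-fold higher number from compound 1 to compound 3 (0.26 log units; within the scatter). Among the measured compounds shown here, no measured compound carries a 4-hydroxyphenyl, so the direction cannot be read from a close precedent; the steps show only that exchanging the aryl group here can move the number in this assay by a large amount or leave it unchanged.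

For compound 4 a step of a 2.3-fold lower number from compound 3 to compound 4 (0.35 log units; beyond the scatter) in this assay is expected, a modest lowering with wide uncertainty. The estimate for compound 4 in this assay is 40 ug/mL, ranging from 8 ug/mL to 150 ug/mL.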

Compound 4, concentration for half-maximal effect: 50 ug/mL
Compound 4: middle estimate off by 1.3-fold (0.10 log units), on the low side; measured number inside the range.
By their numbers in this assay, from the lowest: compound 2; then compounds 1, 4 and 3 (each within the scatter of the next).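

In this assay, 4-hydroxyphenyl joins 3-chlorophenyl and 2-nitrophenyl as a third group that cannot be told apart at this position: neither the exchange for 2-nitrophenyl (a 1.8-fold lower number from compound 3 to compound 4 (0.26 log units; within the scatter)) nor the exchange for 3-chlorophenyl (no change at the digits printed from compound 1 to compound 4 (within the scatter)) leaves the scatter. The result also shows that an aryl group with a hydrogen-bond donor and a single oxygen, with no nitrogen, reads the same in this assay as two aryl groups without a donor, so these differences between the groups do not separate them here. Only 2,4-dichlorophenyl stands apart, now from all three other groups, including the new one (a 25-fold higher number from compound 2 to compound 4 (1.40 log units; beyond the scatter)).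

The compounds shown leave open whether the low number of compound 2 needs both chlorines, which 2-chlorophenyl and 4-chlorophenyl at this position would separate, and whether an aryl group carrying an amine or a carboxylic acid would join the three-group cluster or move away from it. Nothing measured here gives a reason for the gap between compound 2 and the other three compounds.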